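This account rests on a few compounds, and the source may have more. Where it says the series, first, only, none or still open, it means among the compounds named here.

Measured compounds in a functional assay for inhibition, with Homo sapiens as the target; a higher number here means a weaker inhibitor, a lower number a stronger inhibitor:

Compound 1 `CCCc1c(OCCCOc2ccc(C(N)=O)c(OC)c2CCC)ccc2c1OC(C(=O)O)CC2`: 2.7 nM
Compound 2 `CCCc1c(OCCCOc2ccc(C(=O)NC)c(OC)c2CC2CC2)ccc2c1O[C@H](CCC(=O)O)CC2`: 24.4 nM
Compound 3 `CCCc1c(OCCCOc2ccc(C(=O)NC)c(OC)c2CC2CC2)ccc2c1OC(CCC(=O)O)CC2`: 21.9 nM

Among these three, compound 1 has the lowest number, and its gaps to both compound 2 and compound 3 lie beyond the scatter, so it is the strongest inhibitor of the set. Compound 4 `CCCc1c(OCCCOc2ccc(C(=O)NC(C)C)c(OC)c2CCC)ccc2c1OC(C(=O)O)CC2` has not yet been measured. It differs from compound 1 in one place: isopropyl in place of hydrogen on an amide-type nitrogen.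

Going by the values given here, the only measured step here, a 1.1-fold lower number from compound 2 to compound 3 (0.05 log units; within the scatter), concerns the fact that one of compounds 2 and 3 is drawn with a defined configuration and the other without, at the place where they differ and lies within the scatter; it says nothing about a change on the amide nitrogen. Among the compounds with values here, compound 2 and compound 3 do carry a methyl on that nitrogen and give higher numbers than compound 1, but they also differ from compound 1 in other places, so no single step isolates the amide change. Within the data shown here, with no step that bears directly on it, the expectation for compound 4 is a modest rise in this assay, estimated as a 2.2-fold higher number from compound 1 to compound 4 (0.35 log units; beyond the scatter), giving an expected value of 6 nM with a range from 2 nM to 20 nM.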

Compound 4, half-maximal inhibitory concentration: 0.11 nM
Beside the measured number, compound 4's estimate is 55-fold (1.74 log units) above it; the whole stated range lies above it.
By their numbers in this assay, from the lowest: compound 4; then compound 1; then compounds 3 and 2 (each within the scatter of the next).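

In this assay, the amide nitrogen proves to be a highly sensitive place: isopropyl in place of hydrogen gives a 25-fold lower number from compound 1 to compound 4 (1.39 log units; beyond the scatter), a large change from a single substitution. Going by these compounds alone, the earlier compounds could not show this, since the only step among them concerned drawn configuration, and compounds 2 and 3, which carry a methyl on that nitrogen, differ from compound 1 in other places too. Nothing available explains why this substitution has so large an effect.

Going by these compounds, it remains open whether a methyl on the core of compound 1 would give a number between those of compound 1 and compound 4. On these data alone, how a tert-butyl, a cyclopentyl or a 2-hydroxyethyl group on the same nitrogen would read in this assay also remains unknown.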